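The source may hold more compounds than are shown below. What is called first, only, known or untested is meant among the compounds shown, and "the series" means these compounds.

Measured so far in a functional assay on LOX IMVI cells (Homo sapiens) for cytotoxicity, read by MTT assay, with a stated time of 24 h (on this read-out lower numbers stand for stronger inhibition and higher numbers for weaker inhibition), with both compounds sharing the same core:
- compound 1 `COc1cc(-c2nc(-c3ccccc3)[nH]c2-c2ccnc(NCCCNS(=O)(=O)c3ccc(Cl)cc3)n2)ccc1Cl` gives (60900 nM)
- compound 2 `O=S(=O)(NCCCNc1nccc(-c2[nH]c(-c3ccccc3)nc2-c2ccc(F)c(O)c2)n1)c1ccccc1` gives (9580 nM)

Compound 2 (9580 nM) holds the lower of the two numbers, and its gap to compound 1 lies beyond the scatter. The two compounds differ in more than one place, so this gap cannot be tied to any single group.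

The next compound is compound 3 `O=S(=O)(NCCCNc1nccc(-c2[nH]c(-c3ccccc3)nc2-c2ccc(F)c(O)c2)n1)c1ccc(Cl)cc1`, which is compound 2 with chloro in place of hydrogen on an aromatic carbon, para to a large group (chloro in place of hydrogen on an aromatic carbon). Phenylsulfonyl thus becomes (4-chlorophenyl)sulfonyl. Among the measured compounds shown here, no measured pair shows this change alone. Compound 1 (60900 nM) carries the same (4-chlorophenyl)sulfonyl group, but its number cannot be read as the result of the chloro alone. In this assay no step beyond the scatter is therefore expected, and no firm direction can be given. The estimated change (a 1.1-fold lower number from compound 2 to compound 3 (0.03 log units; within the scatter)) is expected to be small. For compound 3 the expected value is 9000 nM (estimated range 3000 nM to 27000 nM).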

Compound 3, half-maximal inhibitory concentration: 14200 nM
Compound 3: middle estimate off by 1.6-fold (0.20 log units), on the low side; low and high end bracket the measured number.
By their numbers in this assay, from the lowest: compounds 2 and 3 (each within the scatter of the next); then compound 1.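

Among the compounds shown here, this is the first matched pair at this position: in this assay, chloro in place of hydrogen on an aromatic carbon, para to a large group, gives a 1.5-fold higher number from compound 2 to compound 3 (0.17 log units; within the scatter), so phenylsulfonyl and (4-chlorophenyl)sulfonyl cannot be told apart in this assay. For the compounds shown here, with (4-chlorophenyl)sulfonyl held fixed, 4-fluoro-3-hydroxyphenyl in place of 4-chloro-3-methoxyphenyl gives a 4.3-fold lower number from compound 1 to compound 3 (0.63 log units; beyond the scatter), the only step beyond the scatter in this set, which places the visible difference on the aryl group rather than on the sulfonyl side. No measurement at hand bears on why either step has the size it has.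

The aryl exchange alters two substituents at once, so the compounds shown do not separate fluoro from chloro or hydroxy from methoxy as the source of that step. Also open, from the compounds shown here alone, is whether an amine or a carboxylic acid in place of the chloro on the phenylsulfonyl ring would give a step beyond the scatter, since a single substituent at this place says little about the position as a whole.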